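Growth inhibition notes: a further methoxy on compound 3

The source may report more compounds than this note shows. Statements on the series, on what has been measured and on what is new or still open speak of the compounds shown alone.

Of the compounds shown here, three sharing one core have been measured in a functional assay on MCF7 cells (Homo sapiens) for inhibition, read by sulforhodamine B assay, with a stated time of 48 h; a higher number here means a weaker inhibitor of growth, a lower number a stronger inhibitor of growth. Compound 1 (`CC1(/C=C/c2ccccc2C(F)(F)F)C=CC(=O)O1`) gives 13500 nM and compound 2 (`CC1(/C=C/c2ccc(C(F)(F)F)cc2)C=CC(=O)O1`) gives 20400 nM, two values within the usual scatter of each other. Compound 3 (`COc1ccc(/C=C/C2(C)C=CC(=O)O2)c(OC)c1`) gives 43500 nM, the highest number of the three. It is therefore the weakest inhibitor of growth in this small set, with its gaps to both others beyond the scatter.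

Compound 4 (`COc1ccc(/C=C/C2(C)C=CC(=O)O2)c(OC)c1OC`) comes from compound 3 by one structural change, methoxy in place of hydrogen on an aromatic carbon, ortho to two methoxy groups. Going by the values given here, no measured pair differs in one place, so no direct precedent exists for this change. Among the compounds with values here, the only anchor is compound 3 at 43500 nM, and the estimate stays close to it. In this assay, on these data alone, no step beyond the scatter is expected, and the direction remains open. The expected change is a 1.1-fold lower number from compound 3 to compound 4 (0.04 log units; within the scatter). Compound 4 is estimated at 40000 nM, with an expected range of 18000 nM to 90000 nM.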

Compound 4, concentration for total growth inhibition: 110000 nM
Estimate against measurement, compound 4: 2.8-fold (0.44 log units) below, and the stated range ends below it.
By their numbers in this assay, from the lowest: compounds 1 and 2 (each within the scatter of the next); then compound 3; then compound 4.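

In this assay the added methoxy on the aromatic carbon, ortho to two methoxy groups and meta to the group of 9 heavy atoms, gives a 2.5-fold higher number from compound 3 to compound 4 (0.40 log units; beyond the scatter) and so moves growth inhibition in the weaker direction. Going by these compounds alone, this is the first one-place step, and it shows that this aromatic carbon of compound 3 does not tolerate every substitution without a change in the read-out, although the step is modest and rests on a single pair. Nothing available accounts for this step, and its origin remains unassigned.

The compounds shown leave open whether the step belongs to methoxy specifically or would also appear with a hydroxyl, a fluorine or a longer chain such as ethoxy on the same carbon. They also leave open whether the same replacement of hydrogen by methoxy would give a similar step on a ring lacking the two methoxy groups of compound 3, such as one carrying only a trifluoromethyl group.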